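The source may hold more compounds than are shown below. What is called first, only, known or untested is meant among the compounds shown, and "the series" means these compounds.

Measured in a functional assay on MCF7 cells (Homo sapiens) for inhibition, with a stated time of 72 h; on this read-out higher numbers stand for weaker inhibition and lower numbers for stronger inhibition:
- compound 1 `NC1CCC(Nc2nc(NCc3ccc(-c4ccsc4)cc3)c3ncn(C4CCCC4)c3n2)CC1`: 145 nM
- compound 2 `NC1CCC(Nc2nc(NCc3cc(Cl)ccc3O)c3ncn(C4CCCC4)c3n2)CC1`: 430 nM

Compound 2, at 430 nM, holds the higher of the two numbers, which makes it the weaker inhibitor of the pair. Compound 3 `Nc1ccccc1CNc1nc(NC2CCC(N)CC2)nc2c1ncn2C1CCCC1` keeps the core and changes one group: 2-aminophenyl in place of 5-chloro-2-hydroxyphenyl on a saturated chain carbon bound to a nitrogen on an aromatic ring. In words, 2-aminophenyl stands in place of 5-chloro-2-hydroxyphenyl on a saturated chain carbon bound to a nitrogen on an aromatic ring. Among the measured compounds shown here, only one measured step bears on this place, a 3.0-fold higher number from compound 1 to compound 2 (0.47 log units; beyond the scatter), which lies beyond the scatter but is modest. For the measured compounds named here, it involves a different pair of groups, and no measurement yet shows what 2-aminophenyl does here. Going by the values given here, with only that modest step as a guide, no shift beyond the scatter is expected in this assay, and the expected step is a 1.1-fold lower number from compound 2 to compound 3 (0.03 log units; within the scatter). For compound 3 the estimate is 400 nM, with an expected range of 130 nM to 1200 nM.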

Compound 3, half-maximal inhibitory concentration: 2330 nM
Compound 3: middle estimate off by 5.8-fold (0.77 log units), on the low side; measured number outside the range, above it.
By their numbers in this assay, from the lowest: compound 1; then compound 2; then compound 3.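

In this assay, the place on a saturated chain carbon bound to a nitrogen on an aromatic ring proves sensitive even to an exchange between two substituted phenyl groups: 2-aminophenyl in place of 5-chloro-2-hydroxyphenyl gives a 5.4-fold higher number from compound 2 to compound 3 (0.73 log units; beyond the scatter), although both groups carry the same counted hydrogen-bond donors and acceptors. Set against 4-(thiophen-3-yl)phenyl, the same group gives a 16-fold higher number from compound 1 to compound 3 (1.21 log units; beyond the scatter), the largest step at this place, and compound 3 now stands as the weakest inhibitor of the three. No measurement to hand accounts for these differences.

The change from compound 2 to compound 3 alters the chlorine and swaps the hydroxyl for an amine at once, so the contribution of each remains unseparated. A 2-hydroxyphenyl or a 5-chloro-2-aminophenyl group at this place would tell the two apart.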